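Hydroxy in Place of Chloro on the Pyridine Ring

The source may report more compounds than this note shows. Statements on the series, on what has been measured and on what is new or still open speak of the compounds shown alone.

In a functional assay on the whole organism with Rattus norvegicus as the target, read by paw edema, with a stated time of 3 h, at a dose of 100 mg/kg by the oral route (a higher number here means more inhibition at the dose given (going by the name of the read-out), a lower number less inhibition), the three measured compounds gave:
compound 1 `CCc1cccc(-c2nc3ccccc3[nH]2)n1`: 41%
compound 2 `OCc1cccc(-c2nc3ccccc3[nH]2)n1`: -13%
compound 3 `Clc1cccc(-c2nc3ccccc3[nH]2)n1`: 30%

Compound 3 stands second highest of the three numbers: a number 11 percentage points lower from compound 1 to compound 3 (beyond the scatter), while a number 43 percentage points higher from compound 2 to compound 3 (beyond the scatter). Compound 4 `Oc1cccc(-c2nc3ccccc3[nH]2)n1` differs from compound 3 in one place: hydroxy in place of chloro on an aromatic carbon. Among the measured compounds shown here, two measured steps bear on this change, each involving a group carrying a hydroxy: a number 54 percentage points lower from compound 1 to compound 2 (beyond the scatter) and a number 43 percentage points higher from compound 2 to compound 3 (beyond the scatter). Both are large, and in both the compound with the hydroxy is the lower one. A large downward step is therefore expected: a number 30 percentage points lower from compound 3 to compound 4 (beyond the scatter). Compound 4 is estimated at 0%, with a range from -25% to 25%.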

Compound 4, a percentage reported as inhibition, in the whole organism at one dose (the size of the read-out at that dose, not a potency): -7%
Beside the measured number, compound 4's estimate is 7 percentage points above it; the range from low to high includes it.
By their numbers in this assay, from the lowest: compounds 2 and 4 (each within the scatter of the next); then compound 3; then compound 1.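

Hydroxy set directly on the aromatic carbon next to the ring nitrogen also reads low in this assay, with a number 37 percentage points lower from compound 3 to compound 4 (beyond the scatter) and a number 48 percentage points lower from compound 1 to compound 4 (beyond the scatter) in the same direction. Until now a hydroxy had been seen only within hydroxymethyl, and a number 6 percentage points higher from compound 2 to compound 4 (within the scatter) leaves the two hydroxy-bearing groups unseparated in this read-out. Nothing measured here accounts for the drop.

Going by these compounds, whether an amine or a carboxylic acid at this place would stay with the two hydroxy-bearing compounds or reach the level of the chloro and ethyl compounds remains open.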